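Amide substituent variation from compound 3 to compound 4

The source may report more compounds than this note shows. Statements on the series, on what has been measured and on what is new or still open speak of the compounds shown alone.

Three members of the series carry the same core and differ only in the group on the carbonyl carbon. Compound 1 `O=C(CCc1ccccc1)Nc1c(C(O)(C(F)(F)F)C(F)(F)F)ccc2ccccc12` gives 1750 nM in an assay on LtK cells with ATP-sensitive inward rectifier potassium channel 11 (Homo sapiens) as the target; on this read-out lower numbers stand for an effect already at smaller amounts and higher numbers for an effect only at larger amounts of compound. Compound 2 `O=C(Nc1ccc(Cl)cc1)Nc1c(C(O)(C(F)(F)F)C(F)(F)F)ccc2ccccc12` gives 276 nM, and compound 3 `O=C(Nc1c(C(O)(C(F)(F)F)C(F)(F)F)ccc2ccccc12)c1cccc(C(F)(F)F)c1` gives 84 nM. The steps run a 6.3-fold lower number from compound 1 to compound 2 (0.80 log units; beyond the scatter), a 21-fold lower number from compound 1 to compound 3 (1.32 log units; beyond the scatter) and a 3.3-fold lower number from compound 2 to compound 3 (0.52 log units; beyond the scatter); compound 3 therefore stands lowest of the three, with compound 2 nearest and compound 1 furthest.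

Compound 4 `O=C(Nc1c(C(O)(C(F)(F)F)C(F)(F)F)ccc2ccccc12)c1ccc(OC(F)(F)F)cc1` is not yet measured. Its change from compound 3 is 4-(trifluoromethoxy)phenyl in place of 3-(trifluoromethyl)phenyl on a carbonyl carbon. For the measured compounds named here, none of the measured steps swaps one aryl amide for another; they only show that an aryl group directly on the carbonyl carbon, as in compound 3, gives the lowest number so far. Going by the values given here, a move of the fluorinated substituent around the ring, with an oxygen entering, has no counterpart in the data, so the expected step is small, within or near the scatter, in either direction. The estimate is a 1.8-fold higher number from compound 3 to compound 4 (0.25 log units; within the scatter). For compound 4 the expected value is 150 nM, with a range from 50 nM to 500 nM.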

Compound 4, half-maximal effective concentration: > 10000 nM
Compound 4: only a limit was reported; the forecaster's own chance of this, stated with the estimate: 3%; at least 66-fold (1.82 log units) between middle value and limit.
By their numbers in this assay, from the lowest: compound 3; then compound 2; then compound 1. At a limit, above all of these: compound 4.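

The aryl group directly on the carbonyl carbon does not by itself give a low number here: 4-(trifluoromethoxy)phenyl in place of 3-(trifluoromethyl)phenyl gives an at least 110-fold higher number from compound 3 to compound 4 (2.07 log units; beyond the scatter). The position therefore separates two aryl amides sharply, and the earlier order of groups no longer holds, with an at least 36-fold higher number from compound 2 to compound 4 (1.55 log units; beyond the scatter) and an at least 5.7-fold higher number from compound 1 to compound 4 (0.75 log units; beyond the scatter), so the aryl amide compound 4 now stands above both compounds that lack an aryl group on that carbon. In this assay compound 4 gives only a limit, not a number: the limit of > 10000 nM in this assay, at which 1 of the 4 values shown sits.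

The compounds shown do not separate the change of ring position from the entry of the oxygen. A 4-(trifluoromethyl)phenyl amide would address this, and an unsubstituted phenyl amide would show what the 3-(trifluoromethyl) group itself contributes.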